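This account rests on a few compounds, and the source may have more. Where it says the series, first, only, none or still open, it means among the compounds named here.

Three compounds built on the shared core have been run in an ADME assay on 2209-23 cells (Homo sapiens) for cytotoxicity, read by WST assay and thymidine incorporation; on this read-out higher numbers stand for lower toxicity in this test and lower numbers for higher toxicity in this test. Compound 1 `CC(=O)C1=C(C2=C(O)[C@H](C(C)(C)C)N(Cc3ccc(F)cc3)C2=O)Nc2ccc(NS(C)(=O)=O)cc2S1(=O)=O` gives > 50000 nM, which is a limit of the assay and not a number. Compound 2 `CC1=C(C2=C(O)[C@H](C(C)(C)C)N(Cc3ccc(F)cc3)C2=O)Nc2ccc(NS(C)(=O)=O)cc2S1(=O)=O` likewise reaches only a limit, > 50000 nM. Compound 3 `CC(C)(C)[C@H]1C(O)=C(C2=C(C#N)S(=O)(=O)c3cc(NS(C)(=O)=O)ccc3N2)C(=O)N1Cc1ccc(F)cc1` also returns a limit, > 50000 nM. All three thus sit together at the limit of > 50000 nM in this assay, at which 3 of the 3 values shown sit, and the steps between them, a step that the two limits leave unreadable from compound 1 to compound 2, a step that the two limits leave unreadable from compound 1 to compound 3 and a step that the two limits leave unreadable from compound 2 to compound 3, cannot be read in either size or direction. Compound 4 `CC(C)(C)[C@H]1C(O)=C(C2=C(C(N)=O)S(=O)(=O)c3cc(NS(C)(=O)=O)ccc3N2)C(=O)N1Cc1ccc(F)cc1` has not yet been measured; it differs from compound 3 by carbamoyl in place of cyano on a double-bonded ring carbon. Among the compounds with values here, no measured step bears on this change; every step lies hidden behind the same limit. The account therefore expects no readable shift, and the step from compound 3 to compound 4 is estimated as a number no higher from compound 3 to compound 4 (the limit leaves the size open). Compound 4 is expected to give 50000 nM, within 25000 nM to 100000 nM, most probably once more reported only as a limit.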

Compound 4, half-maximal cytotoxic concentration: > 50000 nM
Compound 4: only a limit was reported; the forecaster's own chance of this, stated with the estimate: 85%; the middle value sits exactly at the limit.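

In this assay compound 4 gives > 50000 nM as a limit and not a number. Its steps to compound 1, compound 2 and compound 3 therefore cannot be read in size or direction. The compounds shown leave open how far any of the four lies from this limit.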